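Removing One Chloro from a Thiourea Analogue

This account rests on a few compounds, and the source may have more. Where it says the series, first, only, none or still open, it means among the compounds named here.

This account follows a small set of compounds built on a shared core and tested in a functional assay on HeLa cells (Homo sapiens) for antiproliferative activity, with a stated time of 24 h; on this read-out higher numbers stand for weaker inhibition and lower numbers for stronger inhibition. Compound 1 has the structure `NC(=O)c1c(NC(=O)c2ccccc2Cl)sc2c1CCN(Cc1ccccc1Cl)C2` and gives 27500 nM in this assay. Compound 2, with the structure `NC(=O)c1c(NC(=O)c2ccccc2Cl)sc2c1CCN(Cc1ccc(Cl)cc1Cl)C2`, gives 21100 nM in this assay. The two are joined by one change, (hydrogen in place of chloro on an aromatic carbon), and that change made a step of a 1.3-fold higher number from compound 2 to compound 1 (0.12 log units; within the scatter).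

Compound 3 has the structure `NC(=O)c1c(NC(=O)c2ccccc2)sc2c1CCN(C(=S)Nc1ccccc1Cl)C2`. In this assay compound 3 is reported only as a limit, > 50000 nM. How the core of compound 3 differs from that of compound 2 is not broken down here.

Compound 4, still unmeasured, has the structure `NC(=O)c1c(NC(=O)c2ccccc2)sc2c1CCN(C(=S)Nc1ccccc1)C2`. It arises from compound 3 through (hydrogen in place of chloro on an aromatic carbon). For the measured compounds named here, this is the same kind of change as the one from compound 2 to compound 1, though its surroundings differ: in compound 2 the leaving chloro sits meta to a chloro group and para to a large group, whereas in compound 3 it sits ortho to a large group.

Because the earlier step of a 1.3-fold higher number from compound 2 to compound 1 (0.12 log units; within the scatter) stayed within the scatter, and because compound 3 sits at the limit of > 50000 nM in this assay, at which 1 of the 3 values shown sits, the step from compound 3 to compound 4 is expected to be small, about a step that the limit leaves unreadable from compound 3 to compound 4. Compound 4 is therefore estimated at 60000 nM in this assay, with a range from 30000 nM to 150000 nM, and it is likely that only a limit will again be reported.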

Compound 4, half-maximal inhibitory concentration: > 50000 nM
Compound 4 ended at the assay's limit; the forecaster's own chance of this, stated with the estimate: 70%; the middle value does not contradict the limit.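

In this assay compound 4 is reported only as a limit, > 50000 nM. For the compounds shown here, compound 3 is also reported only as a limit, and no step between compound 3 and compound 4 can be read: the limit of > 50000 nM in this assay, at which 2 of the 4 values shown sit. The compounds shown leave open whether the change from 2-chlorophenyl to phenyl shifts antiproliferative activity at all when the thiourea group is present.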